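Pyrazole in place of sulfonamide on the shared core

A few compounds are considered here, and "the series" means these few. Any claim that something is new, unique, unknown or untested is made for them only; others in the source may bear on it.

The series shares the core shown in compound 1 `CS(=O)(=O)Nc1cccc2c1CCC2c1ncc[nH]1`. Within the data shown here, in a functional assay on CHO cells for agonist activity at Alpha-1A adrenergic receptor (Homo sapiens), read by FLIPR and calcium flux (a higher number here means that more compound is needed for the effect, a lower number that less compound is needed), compound 1 gives 70 nM, the second highest of the three numbers so far. Among the measured compounds shown here, compound 2 `Cc1ccc2c(c1NS(C)(=O)=O)CCC2c1ncc[nH]1` gives 33 nM in this assay; the step of a 2.1-fold lower number from compound 1 to compound 2 (0.33 log units; beyond the scatter) is the only single-place change measured, and it adds a methyl only, so it says little about exchanging the methanesulfonamido group. Compound 3 `Clc1ccc2c(c1-c1ccn[nH]1)CCC2c1ncc[nH]1` gives 322 nM in this assay, the highest number shown; no single step joins it to compound 1.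

Compound 4 `Cc1n[nH]cc1-c1cccc2c1CCC2c1ncc[nH]1` differs from compound 1 by 3-methyl-1H-pyrazol-4-yl in place of methanesulfonamido on an aromatic carbon. For the measured compounds named here, no measured step bears directly on this change. Going by the values given here, compound 3, the only measured compound bearing a pyrazole ring, gives 322 nM, higher than compound 1. On that thin basis compound 4 is expected to need more compound, with the step of a 2.9-fold higher number from compound 1 to compound 4 (0.46 log units; beyond the scatter) estimated. Compound 4 is therefore estimated at 200 nM in this assay, with a range from 60 nM to 700 nM.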

Compound 4, half-maximal effective concentration: 3 nM
Estimate against measurement, compound 4: 67-fold (1.82 log units) above; the whole stated range lies above it.
By their numbers in this assay, from the lowest: compound 4; then compound 2; then compound 1; then compound 3.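

Replacing methanesulfonamido with 3-methyl-1H-pyrazol-4-yl on this aromatic carbon gives a 23-fold lower number from compound 1 to compound 4 (1.37 log units; beyond the scatter) in this assay and is a much larger change than the methyl step, a 2.1-fold lower number from compound 1 to compound 2 (0.33 log units; beyond the scatter) on the shared core. A low number at this position therefore does not require the methanesulfonamido group, since a five-membered aromatic ring with 2 hetero atoms and no sulfur serves in its place. No measurement shown accounts for the size of this step.

The compounds shown leave open how much of the step belongs to the methyl group on the pyrazole and whether the methyl step seen between the first two compounds would carry over to compound 4. Also open, as far as these compounds go, is how an unsubstituted pyrazol-4-yl, an amine or a carboxylic acid would read on the same aromatic carbon.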